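The compounds below may be only part of what the source reports. "The series", "measured", "known", "first", "only" and "open" are said of these compounds alone.

Compound 2 `CCc1ccc(-c2cn3ccnc3c(-c3ccc4ncn(C5CCCCC5)c4c3)n2)cc1` is one of two compounds with a shared core measured in a physicochemical assay for lipophilicity, using the shake flask method, in phosphate buffer, measured as octanol-water partition, with a stated time of 85 min, at pH 7.4; a higher number here means a more lipophilic compound, a lower number a more polar compound. Compound 1 `c1ccc(-c2cn3ccnc3c(-c3ccc4ncn(C5CCCCC5)c4c3)n2)cc1` gives 1.74, and compound 2 gives 1.66. Within the data shown here, the only measured step, a number 0.08 log units lower from compound 1 to compound 2 (within the scatter), exchanges hydrogen for ethyl on an aromatic carbon, and on these two numbers compound 2 stands lowest, though the gap to compound 1 lies within the scatter.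

Compound 3 `CC(=O)c1ccc(-c2cn3ccnc3c(-c3ccc4ncn(C5CCCCC5)c4c3)n2)cc1` differs from compound 2 by acetyl in place of ethyl on an aromatic carbon. Among the measured compounds shown here, no measured step here exchanges one group for another on that ring; the single step from compound 1 to compound 2 only adds a group to hydrogen, so it gives no direct anchor. The account therefore rests on the counted difference alone, and a value for compound 3 is expected to come out lower, in this assay, by a number 0.86 log units lower from compound 2 to compound 3 (beyond the scatter). Compound 3 is thus estimated at 0.8, within a range from 0.2 to 1.4.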

Compound 3, partition coefficient: 2.06
Beside the measured number, compound 3's estimate is 1.26 log units below it, and the stated range ends below it.
By their numbers in this assay, from the lowest: compounds 2 and 1 (each within the scatter of the next); then compound 3.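

In this assay, the position para to a large group proves able to shift the number beyond the scatter: acetyl in place of ethyl gives a number 0.40 log units higher from compound 2 to compound 3 (beyond the scatter), and acetyl in place of hydrogen gives a number 0.32 log units higher from compound 1 to compound 3 (beyond the scatter), while the earlier step, a number 0.08 log units lower from compound 1 to compound 2 (within the scatter), stayed within it. The change brings in one hydrogen-bond acceptor and one double bond outside aromatic rings, yet the number rises, so the count of acceptors does not follow the values of these compounds. Nothing shown here explains this rise.

From the compounds shown here alone, it remains open whether an amine or a carboxylic acid at this position would move the number in the same direction as acetyl. Going by these compounds, it is equally open whether a longer chain, such as propyl, would stay within the scatter of compound 1, as ethyl does.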